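Benzyl Ether Replacing Isopropyl Ether in a Translocator Protein Series

The compounds below may be only part of what the source reports. "The series", "measured", "known", "first", "only" and "open" are said of these compounds alone.

Compound 1, `CCN(CC)C(=O)CN(Cc1ccc(OCCF)cc1)c1cc(C)cc(C)c1`, gives > 10000 nM in an assay on HEK293 cells for displacement of a labelled ligand from Translocator protein (Homo sapiens), read by scintillation counting, with a stated time of 90 min; a higher number here means a weaker inhibitor, a lower number a stronger inhibitor.
Compound 2, `CCN(CC)C(=O)CN(Cc1ccc(OC(C)C)cc1)c1cc(C)cc(C)c1`, gives > 10000 nM in this assay.

Compound 2 stands at the limit of > 10000 nM in this assay, at which 2 of the 2 values shown sit; its value is a limit of the assay, not a number. Among the measured compounds shown here, the single measured step, a step that the two limits leave unreadable from compound 1 to compound 2, is therefore unreadable in size. Compound 3, `CCN(CC)C(=O)CN(Cc1ccc(OCc2ccccc2)cc1)c1cc(C)cc(C)c1`, differs by benzyl in place of isopropyl on an oxygen on an aromatic ring. No readable step bears on this change, so no direction beyond the scatter can be expected. Compound 3 is estimated at 10000 nM, within 2000 nM to 50000 nM. The expected step is a number no higher from compound 2 to compound 3 (the limit leaves the size open).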

Compound 3, inhibition constant: 1770 nM
The estimate for compound 3 lay 5.6-fold (0.75 log units) above the measured number; the whole stated range lies above it.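

On an oxygen on an aromatic ring, benzyl brings a readable number in this assay, which neither isopropyl nor 2-fluoroethyl did. Benzyl in place of isopropyl gives an at least 5.6-fold lower number from compound 2 to compound 3 (0.75 log units; beyond the scatter), and the change from the 2-fluoroethyl ether gives an at least 5.6-fold lower number from compound 1 to compound 3 (0.75 log units; beyond the scatter). Compound 1 and compound 2 each stand at a limit of the assay, so the true size of both steps stays open: the limit of > 10000 nM in this assay, at which 2 of the 3 values shown sit.

The compounds shown cannot separate the aromatic ring of benzyl from its larger count of carbons. A cyclohexylmethyl group on the same oxygen would put that question to the test.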